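The compounds below may be only part of what the source reports. "The series", "measured", "known", "first", "only" and "open" are said of these compounds alone.

Measured compounds:
Compound 1 `Cc1ccc(Nc2nc(Cl)nc3c2ncn3Cc2ccc(/C=C/C(=O)Nc3ccccc3N)cc2)cc1` gives 15% in a functional assay on HCT-116 cells (Homo sapiens) for antiproliferative activity, read by CCK-8 assay, with a stated time of 72 h, tested at 8 uM; a higher number here means a stronger effect of the compound at the concentration tested, a lower number a weaker effect.
Compound 2 `Nc1ccccc1NC(=O)/C=C/c1ccc(Cn2cnc3c(Nc4cccc(OC(F)(F)F)c4)nc(Cl)nc32)cc1` gives 5.23% in this assay.

Among the compounds with values here, compound 2 and compound 1 sit within the scatter of each other in this assay, the only step between them being a number 9.8 percentage points lower from compound 1 to compound 2 (within the scatter), so neither number separates from the other. Compound 3 `Nc1ccccc1NC(=O)/C=C/c1ccc(Cn2cnc3c(NC4CCCCC4)nc(Cl)nc32)cc1` is the compound not yet measured; it differs from compound 2 by cyclohexyl in place of 3-(trifluoromethoxy)phenyl on a nitrogen on an aromatic ring. Within the data shown here, the one measured step that touches the same nitrogen on the shared core, a number 9.8 percentage points lower from compound 1 to compound 2 (within the scatter), exchanged one aromatic group for another and stayed within the scatter; no measured step exchanges an aromatic group for a non-aromatic ring at that place, so its bearing on compound 3 is only indirect. Compound 3 is therefore expected to show a step of a number 3.8 percentage points higher from compound 2 to compound 3 (within the scatter) in this assay, that is, nothing beyond the scatter. The estimate for compound 3 is 9%, with a range from 0% to 25%.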

Compound 3, a percentage reported as inhibition, at one concentration (the size of the read-out at that concentration, not a potency): 18.7%
Compound 3: middle estimate off by 9.7 percentage points, on the low side; low and high end bracket the measured number.
By their numbers in this assay, from the lowest: compounds 2, 1 and 3 (each within the scatter of the next, the first and the last beyond it).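

Within the data shown here, compound 3 alone among the three carries a non-aromatic ring on this nitrogen, and in this assay the exchange of 3-(trifluoromethoxy)phenyl for cyclohexyl gives the only step at this position that clears the scatter, a number 13.5 percentage points higher from compound 2 to compound 3 (beyond the scatter), though it is modest. Against 4-methylphenyl the same ring gives a number 3.7 percentage points higher from compound 1 to compound 3 (within the scatter), which stays within the scatter, so leaving the aromatic ring does not by itself separate compound 3 from both aromatic partners; only the pair with compound 2 comes apart. Nothing at hand accounts for this difference between the groups.

The compounds shown leave open whether a ring is needed here at all, since an open-chain n-butyl group on the same nitrogen does not appear among them. They also leave open how a six-membered ring holding an oxygen, such as tetrahydropyranyl, or a smaller cyclopentyl ring would read in this assay.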